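Amide substituent change from compound 3 to compound 4

The source may hold more compounds than are shown below. What is called first, only, known or untested is meant among the compounds shown, and "the series" means these compounds.

Measured in a functional assay on BXPC-3 cells (Homo sapiens) for antiproliferative activity, read by MTT assay, with a stated time of 24 h; a lower number here means a stronger inhibitor, a higher number a weaker inhibitor
- compound 1 `CCn1c(C(=O)NCCNC(=O)OC(C)(C)C)ccc1C(CC)(CC)c1ccc(OCS(=O)(=O)c2ccccc2)c(C)c1` gives > 50000 nM as a limit of the assay
- compound 2 `CCn1c(C(=O)NCCN)ccc1C(CC)(CC)c1ccc(OCS(=O)(=O)c2ccccc2)c(C)c1` gives 6430 nM
- compound 3 `CCn1c(C(=O)N[C@@H](CO)C(C)C)ccc1C(CC)(CC)c1ccc(OCS(=O)(=O)c2ccccc2)c(C)c1` gives 13200 nM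

Compound 3 holds the higher of the two exact numbers, with a 2.1-fold higher number from compound 2 to compound 3 (0.31 log units; beyond the scatter) as a modest step. Compound 4 `CCn1c(C(=O)N[C@H](CO)CCO)ccc1C(CC)(CC)c1ccc(OCS(=O)(=O)c2ccccc2)c(C)c1` differs from it by 3-hydroxy-1-(hydroxymethyl)propyl in place of 1-(hydroxymethyl)-2-methylpropyl on an amide-type nitrogen on the same nitrogen: 3-hydroxy-1-(hydroxymethyl)propyl in place of 1-(hydroxymethyl)-2-methylpropyl. That modest step bears most directly, since it also changes this substituent. The step of an at least 3.7-fold lower number from compound 1 to compound 3 (0.57 log units; beyond the scatter) also bears on it, but it rests on a limit. Neither step makes this exact exchange, so only a small change is expected in this assay, with no step beyond the scatter and no firm direction. The expected step is a 1.1-fold higher number from compound 3 to compound 4 (0.06 log units; within the scatter) in this assay. Compound 4 is estimated at 15000 nM within a range of 6000 nM to 40000 nM for now.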

Compound 4, half-maximal inhibitory concentration: 15900 nM
For compound 4 the middle estimate is 1.1-fold (0.03 log units) below the measured one; the range from low to high includes it.
By their numbers in this assay, from the lowest: compound 2; then compounds 3 and 4 (each within the scatter of the next). At a limit, above all of these: compound 1.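

In this assay, exchanging 1-(hydroxymethyl)-2-methylpropyl for 3-hydroxy-1-(hydroxymethyl)propyl on the amide-type nitrogen leaves the number within the scatter, with a 1.2-fold higher number from compound 3 to compound 4 (0.08 log units; within the scatter). The 2-aminoethyl group also keeps the lower number against this new substituent, with a 2.5-fold higher number from compound 2 to compound 4 (0.39 log units; beyond the scatter). The step of an at least 3.1-fold lower number from compound 1 to compound 4 (0.49 log units; beyond the scatter) is a bound only, as its starting number is a limit of the assay: the limit of > 50000 nM in this assay, at which 1 of the 4 values shown sits.

From the compounds shown here alone, whether a carboxylic acid or a longer aminoalkyl chain on this nitrogen would fall below the 2-aminoethyl number remains open. Going by these compounds, the opposite configuration of either hydroxyl-bearing substituent also remains open.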